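Cytotoxicity notes on a matched pair and its analogue

The source may hold more compounds than are shown below. What is called first, only, known or untested is meant among the compounds shown, and "the series" means these compounds.

Measured so far:
Compound 1, `O=C(CN1CCN(c2ccccc2Cl)CC1)N1CCN(c2nnc(-c3ccccc3)c(-c3ccccc3)n2)CC1`, gives 350000 nM.
Compound 2, `COc1cccc(N2CCN(CC(=O)N3CCN(c4nnc(-c5ccccc5)c(-c5ccccc5)n4)CC3)CC2)c1`, gives 361000 nM.
Compound 3, `O=C(CN1CCN(c2ccccc2Cl)CC1)N1CCN(c2nnc(-c3ccc(Cl)cc3)c(-c3ccc(Cl)cc3)n2)CC1`, is recorded only as a limit of the assay, > 803000 nM.

All three values come from an ADME assay on NIH3T3 cells (Mus musculus) for cytotoxicity, read by MTT assay, with a stated time of 24 h; on this read-out lower numbers stand for stronger inhibition and higher numbers for weaker inhibition. The change from compound 1 to compound 2 is 3-methoxyphenyl in place of 2-chlorophenyl on an amine nitrogen in a ring. It gave a 1.0-fold higher number from compound 1 to compound 2 (0.01 log units; within the scatter), so the two values cannot be ranked against each other. Compound 3 shares the change-bearing part with compound 1 but carries a different core; how the two cores differ is not broken down here. For compound 3 the assay reports no number, only (the limit of > 803000 nM in this assay, at which 1 of the 3 values shown sits).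

Compound 4, `COc1cccc(N2CCN(CC(=O)N3CCN(c4nnc(-c5ccc(Cl)cc5)c(-c5ccc(Cl)cc5)n4)CC3)CC2)c1`, is the not yet measured partner of compound 3. The change from compound 3 to compound 4 is 3-methoxyphenyl in place of 2-chlorophenyl on an amine nitrogen in a ring. The place description matches that of the change from compound 1 to compound 2 word for word, so this is the same change made on the other core. Within the data shown here, the only measured instance of it is a 1.0-fold higher number from compound 1 to compound 2 (0.01 log units; within the scatter), which sits within the scatter; on that basis a step of similar size is expected here, that is a step that the limit leaves unreadable from compound 3 to compound 4 as an expectation. Because compound 3 itself stands at the limit of > 803000 nM in this assay, at which 1 of the 3 values shown sits, compound 4 is more likely than not to come back as a limit as well. Compound 4 is estimated at 900000 nM, with an expected range from 450000 nM to 2000000 nM in this assay .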

Compound 4, half-maximal inhibitory concentration: 202000 nM
The estimate for compound 4 lay 4.5-fold (0.65 log units) above the measured number; measured number below the stated range.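

Carrying this change from one core to the other does not give the same result in this assay: the same change on two cores in this assay, a 1.0-fold higher number (0.01 log units; within the scatter) from compound 1 to compound 2 and an at least 3.9-fold lower number (0.59 log units; beyond the scatter) from compound 3 to compound 4, at least 4.1-fold (0.61 log units) apart, beyond the scatter of two such steps

On the core of compound 3, 3-methoxyphenyl in place of 2-chlorophenyl on an amine nitrogen in a ring gives an at least 3.9-fold lower number from compound 3 to compound 4 (0.59 log units; beyond the scatter), so the near-silent result seen on the core of compound 1 cannot be assumed to hold on every core in this series, although one pair per core sets no rule and does not identify which part of the cores matters. Compound 3 is recorded only as a limit, so the step sets a minimum size and its full size stays unknown: the limit of > 803000 nM in this assay, at which 1 of the 4 values shown sits.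

The compounds shown leave open whether other groups on the same amine nitrogen, such as a phenyl ring carrying a nitrile or a carboxylic acid, would also separate the two cores in this way. They also leave open whether a third core would follow the core of compound 1, the core of compound 3, or neither when 3-methoxyphenyl replaces 2-chlorophenyl.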